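Uridine diphosphate analogues at the P2Y6 receptor

The source may hold more compounds than are shown below. What is called first, only, known or untested is meant among the compounds shown, and "the series" means these compounds.

Three compounds have been characterised in an in vitro functional assay on 1321-N1 cells for agonist activity at P2Y purinoceptor 6 (Homo sapiens); on this read-out lower numbers stand for an effect already at smaller amounts and higher numbers for an effect only at larger amounts of compound. Compound 1 `O=c1ccn([C@@H]2O[C@H](COP(=O)(O)OP(=O)(O)O)C[C@H]2O)c(=O)[nH]1` gives 2500 nM, compound 2 `O=c1nc(SCc2ccccc2)ccn1[C@@H]1O[C@H](COP(=O)(O)OP(=O)(O)O)[C@@H](O)[C@H]1O` gives 800 nM, and compound 3 `O=c1ccn([C@]23CC2[C@H](COP(=O)(O)OP(=O)(O)O)[C@@H](O)C3)c(=O)[nH]1` gives 230 nM. Compound 2 therefore holds the second highest number of the three: compound 1 stands higher and compound 3 lower, and both gaps are beyond the scatter of repeated measurements. None of these pairs differs at a single place, so no single-point step can be read from them.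

Compound 4 `CCSc1ccn([C@@H]2O[C@H](COP(=O)(O)OP(=O)(O)O)[C@@H](O)[C@H]2O)c(=O)n1` is derived from compound 2 by one change, methyl in place of phenyl on a saturated chain carbon bound to a sulfur — benzyl to ethyl, or benzylsulfanyl to ethylsulfanyl. For the measured compounds named here, with no measured step of this kind available, the size of the effect in this assay is open. The author expects a modest shift towards a higher number, a 1.9-fold higher number from compound 2 to compound 4 (0.27 log units; within the scatter), though a result within the scatter would not surprise. The estimate for compound 4 is 1500 nM, with a plausible range from 400 nM to 5000 nM.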

Compound 4, half-maximal effective concentration: 280 nM
Compound 4: the middle estimate sits 5.4-fold (0.73 log units) above what was measured; measured number outside the range, below it.
By their numbers in this assay, from the lowest: compounds 3 and 4 (each within the scatter of the next); then compound 2; then compound 1.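

For the compounds shown here, the change from phenyl to methyl on a saturated chain carbon bound to a sulfur, benzylsulfanyl to ethylsulfanyl, gives in this assay a 2.9-fold lower number from compound 2 to compound 4 (0.46 log units; beyond the scatter) and is the first single-place step available. It shows that the phenyl with its six-membered aromatic ring is not needed at this position for an effect on this read-out, since the much smaller methyl goes with an effect at smaller amounts of compound. The compounds shown offer no evidence on why the number falls with this change.

As far as these compounds go, it remains open whether a longer chain on the sulfur, such as propyl, would continue or reverse this shift, and whether an amine could take the place of the ethylsulfanyl group. Whether the same change would carry over to the core of compound 3 is also unresolved.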